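The compounds below may be only part of what the source reports. "The series", "measured", "known", "first", "only" and "open" are said of these compounds alone.

Measured in a functional assay on B16-F10 cells (Mus musculus) for antiproliferative activity, read by MTT assay, with a stated time of 48 h; on this read-out lower numbers stand for stronger inhibition and higher numbers for weaker inhibition:
- compound 1 `CC(=O)N1N=C(c2ccc3ccccc3c2)OC1c1ccccc1`: 2.57 ug/mL
- compound 2 `CC(=O)N1N=C(c2ccc3ccccc3c2)OC1c1ccccc1F`: 6.05 ug/mL
- compound 3 `CC(=O)N1N=C(c2ccc3ccccc3c2)OC1c1ccc2ccccc2c1`: 1.56 ug/mL

Of the three, compound 2 carries the highest number, at 6.05 ug/mL, and the gaps to compound 1 and compound 3 both lie beyond the scatter. The next analogue is compound 4 `CC(=O)N1N=C(c2ccc3ccccc3c2)OC1c1ccccn1`, which has pyridin-2-yl in place of 2-fluorophenyl on a saturated ring carbon of the five-membered non-aromatic ring: pyridin-2-yl in place of 2-fluorophenyl on a saturated ring carbon.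

Within the data shown here, only one measured step bears on this change, a 2.4-fold higher number from compound 1 to compound 2 (0.37 log units; beyond the scatter), a modest rise on putting fluoro in place of hydrogen on an aromatic carbon. Compound 4 has no fluoro, so part of that rise may be reversed. However, no measured compound has an aromatic ring with a hetero atom in this place, so the data give no direct guide to that part of the change. The expected move is small and toward a lower number, a 1.5-fold lower number from compound 2 to compound 4 (0.18 log units; within the scatter). The estimate for compound 4 is 4 ug/mL, with an expected range of 1.8 ug/mL to 9 ug/mL.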

Compound 4, half-maximal inhibitory concentration: 7.18 ug/mL
Compound 4: the middle estimate sits 1.8-fold (0.25 log units) below what was measured, and the stated range covers the measured number.
By their numbers in this assay, from the lowest: compounds 3 and 1 (each within the scatter of the next); then compounds 2 and 4 (each within the scatter of the next).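

In this assay, pyridin-2-yl at this saturated ring carbon gives a 2.8-fold higher number from compound 1 to compound 4 (0.45 log units; beyond the scatter), so a second replacement of phenyl, after 2-fluorophenyl, also ends beyond the scatter on the higher side. The other step, a 1.2-fold higher number from compound 2 to compound 4 (0.07 log units; within the scatter), shows that 2-fluorophenyl and pyridin-2-yl cannot be told apart here, and the absence of fluoro in compound 4 does not bring its number back to that of compound 1. No measured evidence is available to explain either step.

Going by these compounds, it remains open whether a small phenyl substituent other than fluoro, such as methoxy, an amine or a carboxylic acid, would also give a higher number than phenyl. A saturated group at this carbon, such as cyclohexyl, also remains untested in the compounds shown here.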